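This account rests on a few compounds, and the source may have more. Where it says the series, first, only, none or still open, it means among the compounds named here.

Of the compounds shown here, three sharing one core have been tested in a functional assay on the whole organism (strain albino) for inhibition, with Rattus norvegicus as the target, read by paw edema, with stated times of 1 h and 3 h, at a dose of 20 mmol/kg by the intraperitoneal route; a lower number here means a weaker effect, a higher number a stronger effect of the compound at the dose given. Compound 1 `N#CC1=C(NCC(=O)N2CCOCC2)N(c2ccccc2)C(=O)N2CCCCC(N3CCCC3)C12` gives 73.5%. Compound 2 `N#CC1=C(NCC(=O)O)N(c2ccccc2)C(=O)N2CCCCC(N3CCCC3)C12` gives 89.2%, the step being a number 15.7 percentage points higher from compound 1 to compound 2 (beyond the scatter). Compound 3 `N#CC1=C(NCN2CCCCC2)N(c2ccccc2)C(=O)N2CCCCC(N3CCCC3)C12` gives 42.1%, the lowest of the three numbers: the steps to it were a number 31.4 percentage points lower from compound 1 to compound 3 (beyond the scatter) and a number 47.1 percentage points lower from compound 2 to compound 3 (beyond the scatter). Compound 4 `N#CC1=C(/N=C/c2ccccc2)N(c2ccccc2)C(=O)N2CCCCC(N3CCCC3)C12` has not been measured; it differs from compound 3 by a group of 8 heavy atoms (7 carbon, 1 nitrogen; one six-membered aromatic ring of carbon only) in place of a group of 8 heavy atoms (6 carbon, 2 nitrogen; one six-membered non-aromatic ring with 1 hetero atom), on a double-bonded ring carbon. Both measured steps that reached compound 3 exchanged a group at the same place on the core, and each was large, so a sizeable step is plausible here as well, though its direction cannot be read from them. Compound 4 is therefore expected to give 55%, within 28% to 80%. The step this estimate implies is a number 12.9 percentage points higher from compound 3 to compound 4 (beyond the scatter).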

Compound 4, a percentage reported as inhibition, in the whole organism at one dose (the size of the read-out at that dose, not a potency): 84%
Beside the measured number, compound 4's estimate is 29 percentage points below it, and the stated range ends below it.
By their numbers in this assay, from the lowest: compound 3; then compound 1; then compounds 4 and 2 (each within the scatter of the next).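

At this double-bonded ring carbon, replacing ((piperidin-1-yl)methyl)amino with the entering group, which carries a six-membered aromatic ring of carbon only, gives a number 41.9 percentage points higher from compound 3 to compound 4 (beyond the scatter). The same group also gives a number 10.5 percentage points higher from compound 1 to compound 4 (beyond the scatter), and a number 5.2 percentage points lower from compound 2 to compound 4 (within the scatter), so a group without a carboxy function can match the carboxy-bearing compound 2 here. High numbers at this place therefore do not depend on the carboxy group.

Nothing available explains these steps. From the compounds shown here alone, it remains open whether a pyridine ring in place of the entering group's phenyl, or a plain amine at this carbon, would reach similar numbers.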